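Swapping the aryl group on a shared core

The source may hold more compounds than are shown below. What is called first, only, known or untested is meant among the compounds shown, and "the series" means these compounds.

Of the compounds shown here, three built on one shared core have been measured. In an assay on CHO cells for displacement of a labelled ligand from adenosine receptor A1 (Homo sapiens), read by scintillation counting, tested at 10 uM (a higher number here means more inhibition at the concentration tested (going by the name of the read-out), a lower number less inhibition), compound 1 `CC(C)(C)Cc1c(-c2c(F)cccc2F)sc(N)c1C(=O)c1ccc(Cl)cc1` gives 1%. In this assay compound 2 `CC(C)(C)Cc1c(-c2ccc(Cl)cc2)sc(N)c1C(=O)c1ccc(Cl)cc1` gives 1%, and compound 3 `COc1ccc(-c2sc(N)c(C(=O)c3ccc(Cl)cc3)c2CC(C)(C)C)cc1` gives 1%. The step of no change at the digits printed from compound 1 to compound 2 (within the scatter) and the step of no change at the digits printed from compound 1 to compound 3 (within the scatter) both stay within the scatter, as does the step of no change at the digits printed from compound 2 to compound 3 (within the scatter). Compound 3 therefore stands level with compounds 1 and 2; on these numbers its nearest neighbour is compound 1 and its furthest is compound 2, yet neither gap goes beyond the scatter.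

Compound 4 `CC(C)(C)Cc1c(-c2ccsc2)sc(N)c1C(=O)c1ccc(Cl)cc1` differs from compound 3 in one place: thiophen-3-yl in place of 4-methoxyphenyl on an aromatic carbon. All three measured steps, each exchanging the aryl group at that same ring carbon, bear on this change, and each of them left the read-out unchanged within the scatter. For compound 4 the expected step is therefore a number 1 percentage points higher from compound 3 to compound 4 (within the scatter), nothing beyond the scatter. Compound 4 is expected to give 2% in this assay, within an estimated range from -8% to 13%.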

Compound 4, a percentage reported as inhibition, at one concentration (the size of the read-out at that concentration, not a potency): 2%
Compound 4: the middle estimate sits on the measured number at the digits printed, and the stated range covers the measured number.
By their numbers in this assay, from the lowest: compounds 1, 2, 3 and 4 (each within the scatter of the next).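

Up to now every group at this ring carbon carried a six-membered aromatic ring of carbon only, whereas thiophen-3-yl brings a five-membered aromatic ring with a sulfur and 5 heavy atoms against the 8 of 4-methoxyphenyl. In this assay this different kind of ring still leaves the read-out flat, with a number 1 percentage points higher from compound 3 to compound 4 (within the scatter) and a number 1 percentage points higher from compound 2 to compound 4 (within the scatter) and a number 1 percentage points higher from compound 1 to compound 4 (within the scatter) so that neither ring size nor a ring hetero atom at this position separates the four compounds. Nothing measured here offers an explanation for this flat result.

From the compounds shown here alone, all the groups at this carbon so far are aromatic rings, so it remains open whether an amine, a carboxylic acid or a longer chain there would shift the read-out. Also open, going by these compounds, is what replacing the neopentyl group or the (4-chlorophenyl)carbonyl group would do.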